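Working notes on an alkyl shortening in the series

The source may report more compounds than this note shows. Statements on the series, on what has been measured and on what is new or still open speak of the compounds shown alone.

Measured so far:
compound 1 `CCC/N=C(/NC#N)NCCCn1nc(-c2ccccc2)ccc1=O`, 100 mg/kg
compound 2 `C/N=C(/NC#N)NCCCCCn1nc(-c2ccccc2)c(C)cc1=O`, > 100 mg/kg
compound 3 `CC/N=C(/NC#N)NCCCCn1nc(-c2ccccc2)ccc1=O`, 92 mg/kg

In a functional assay on the whole organism (stomach) with Rattus norvegicus as the target (on this read-out lower numbers stand for an effect already at smaller amounts and higher numbers for an effect only at larger amounts of compound), compound 1 gives 100 mg/kg. Compound 3 gives 92 mg/kg in this assay, and the two numbers lie within the scatter of each other, so no order between compound 1 and compound 3 can be read from them. For compound 2 the assay reports only a limit, > 100 mg/kg, which is the limit of > 100 mg/kg in this assay, at which 1 of the 3 values shown sits. Compound 4 `CC/N=C(/NC#N)NCCCn1nc(-c2ccccc2)ccc1=O` is not yet measured. It differs from compound 1 by hydrogen in place of methyl on a saturated chain carbon, two bonds along the chain from a double-bonded nitrogen. Within the data shown here, compound 3 carries the ethyl, on a longer chain than compound 4, and sits close to compound 1; no measured pair shares exactly the change at hand. The shortening is expected to move the read-out little, a 1.1-fold lower number from compound 1 to compound 4 (0.02 log units; within the scatter), with no direction beyond the scatter. Compound 4 is expected to give about 95 mg/kg in this assay, between 45 mg/kg and 190 mg/kg.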

Compound 4, dose for half-maximal effect: 78.3 mg/kg
Beside the measured number, compound 4's estimate is 1.2-fold (0.08 log units) above it; the range from low to high includes it.
By their numbers in this assay, from the lowest: compounds 4, 3 and 1 (each within the scatter of the next).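

Hydrogen in place of methyl on a saturated chain carbon, two bonds along the chain from a double-bonded nitrogen, which here reads as propyl to ethyl, gives in this assay a 1.3-fold lower number from compound 1 to compound 4 (0.11 log units; within the scatter). Among these compounds, the earlier compounds differ from one another in more than one place, so this is the first direct reading at this position: on the core of compound 1, removing this one carbon leaves the read-out within the scatter. The compounds shown offer no measured basis for a cause of this step.

Going by these compounds, it remains open whether a methyl, a butyl or a benzyl group in this place, or a chain ending in an amine or a hydroxyl, would shift the number beyond the scatter. Also open, on these data alone, is whether propyl to ethyl reads the same on the longer chain of compound 3.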